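Amino in Place of Hydroxy on Compound 3

A few compounds are considered here, and "the series" means these few. Any claim that something is new, unique, unknown or untested is made for them only; others in the source may bear on it.

Of the compounds shown here, three built on one core have been measured in an assay on cells for inhibition of Indoleamine 2,3-dioxygenase 1 (Homo sapiens), read by HPLC, with a stated time of 20 min; on this read-out lower numbers stand for stronger inhibition and higher numbers for weaker inhibition. Compound 1 `Clc1cccc(-n2ccnc2)c1` gives 41000 nM, compound 2 `Nc1ccccc1-n1ccnc1` gives 1300000 nM, and compound 3 `Oc1ccc(Cl)cc1-n1ccnc1` gives 2100 nM, the lowest of the three numbers. Going by the values given here, the single measured step among them, a 20-fold lower number from compound 1 to compound 3 (1.29 log units; beyond the scatter), shows the weight of the hydroxy group on this core. Compound 4 `Nc1ccc(Cl)cc1-n1ccnc1` differs from compound 3 by amino in place of hydroxy on an aromatic carbon. Among the compounds with values here, no measured step covers this exchange; the only guide is compound 2, which carries the amino group without the chloro group and gives 1300000 nM, far above the number for compound 3. Compound 4 is therefore expected to be weaker, with an estimated step of a 38-fold higher number from compound 3 to compound 4 (1.58 log units; beyond the scatter). The number for compound 4 in this assay is estimated at 80000 nM, within a range from 10000 nM to 600000 nM.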

Compound 4, half-maximal inhibitory concentration: 88000 nM
Beside the measured number, compound 4's estimate is 1.1-fold (0.04 log units) below it, within the range that was stated.
By their numbers in this assay, from the lowest: compound 3; then compound 1; then compound 4; then compound 2.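

In this assay, the exchange gives a 42-fold higher number from compound 3 to compound 4 (1.62 log units; beyond the scatter) and shows that amino does not stand in for hydroxy at this position. Amino in place of hydrogen gives a 2.1-fold higher number from compound 1 to compound 4 (0.33 log units; beyond the scatter) while hydroxy in place of hydrogen gives a 20-fold lower number from compound 1 to compound 3 (1.29 log units; beyond the scatter) so the two groups move the number in opposite directions on this core, and the chloro group still counts with amino present, as a 15-fold lower number from compound 2 to compound 4 (1.17 log units; beyond the scatter) shows. Nothing at hand explains these differences. Still open, as far as these compounds go, is how a methoxy group or a carboxylic acid would read at this position, and whether a bromo group could replace the chloro group.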